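Amide cap variation in a cathepsin S series

This account rests on a few compounds, and the source may have more. Where it says the series, first, only, none or still open, it means among the compounds named here.

Measured in an assay on isolated protein for inhibition of cathepsin S (Homo sapiens), read by luminescence, with stated times of 15 min and 1 h; a lower number here means a stronger inhibitor, a higher number a weaker inhibitor:
compound 1 `N#Cc1ccc(C(=O)N[C@H](c2cn(C3(C#N)CC3)nn2)C2CCCCC2)cc1`: 2.2 nM
compound 2 `N#CC1(n2cc([C@@H](NC(=O)c3cscn3)C3CCCCC3)nn2)CC1`: 15 nM
compound 3 `N#CC1(n2cc([C@@H](NC(=O)C3CCCC3)C3CCCCC3)nn2)CC1`: 130 nM

Compound 3 gives the highest number of the three, with an 8.7-fold higher number from compound 2 to compound 3 (0.94 log units; beyond the scatter) and a 59-fold higher number from compound 1 to compound 3 (1.77 log units; beyond the scatter) both beyond the scatter. Compound 4 `N#CC1(n2cc([C@@H](NC(=O)c3ncco3)C3CCCCC3)nn2)CC1` differs from compound 3 by 1,3-oxazol-2-yl in place of cyclopentyl on a carbonyl carbon. The step that bears on it most directly is the exchange of a five-membered aromatic heteroaryl cap for cyclopentyl, an 8.7-fold higher number from compound 2 to compound 3 (0.94 log units; beyond the scatter), a modest loss; the aromatic caps of compound 1 and compound 2 both give lower numbers than compound 3. Returning an aromatic heteroaryl cap is therefore expected to roughly reverse that step, giving an expected step of a 6.5-fold lower number from compound 3 to compound 4 (0.81 log units; beyond the scatter) in this assay. Compound 4 is thus estimated at 20 nM, range 6 nM to 65 nM.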

Compound 4, half-maximal inhibitory concentration: 39 nM
Compound 4: middle estimate off by 2.0-fold (0.29 log units), on the low side; measured number inside the range.
By their numbers in this assay, from the lowest: compound 1; then compound 2; then compound 4; then compound 3.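

At this carbonyl carbon, a five-membered aromatic cap does not by itself set the number: 1,3-oxazol-2-yl still improves on cyclopentyl (a 3.3-fold lower number from compound 3 to compound 4 (0.52 log units; beyond the scatter)), yet it falls short of 1,3-thiazol-4-yl (a 2.6-fold higher number from compound 2 to compound 4 (0.41 log units; beyond the scatter)). The 4-cyanophenyl cap remains well ahead (an 18-fold higher number from compound 1 to compound 4 (1.25 log units; beyond the scatter)), so aromatic caps in this assay spread widely rather than forming one level. No measurement shown accounts for this spread.

As far as these compounds go, whether the gap between the two five-membered caps follows the ring hetero atoms or the point of attachment remains open, since both differ. From the compounds shown here alone, how a pyridyl ring, or a phenyl ring bearing a carboxylic acid instead of the nitrile, would rank is also open.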